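The source may hold more compounds than are shown below. What is called first, only, known or untested is meant among the compounds shown, and "the series" means these compounds.

Measured in a functional assay on MCF7 cells (Homo sapiens) for antiproliferative activity, read by CellTiter-Glo, with a stated time of 5 days; a lower number here means a stronger inhibitor, a higher number a weaker inhibitor:

Compound 1 `CC/C(=C(/c1ccc(/C=C/C(=O)O)cc1)c1ccn2nccc2c1)c1ccccc1`: > 500 nM, a limit.
Compound 2 `CC/C(=C(/c1ccc(/C=C/C(=O)O)cc1)c1ccc2ocnc2c1)c1ccccc1`: > 500 nM, a limit.
Compound 3 `CC/C(=C(/c1ccc(/C=C/C(=O)O)cc1)c1ccc(-c2cncs2)cc1)c1ccccc1`: 31 nM.

Compound 3 is the only one of these with an actual number. Compounds 1 and 2 stand at the limit of > 500 nM in this assay, at which 2 of the 3 values shown sit. Still unmeasured is compound 4 `CC/C(=C(/c1ccc(/C=C/C(=O)O)cc1)c1ccc(N2CCN(C)CC2)cc1)c1ccccc1`, which carries 4-methylpiperazin-1-yl in place of 1,3-thiazol-5-yl on an aromatic carbon, para to a large group: 4-methylpiperazin-1-yl in place of 1,3-thiazol-5-yl on an aromatic carbon.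

Among the compounds with values here, the one measured step in the set is a step that the two limits leave unreadable from compound 1 to compound 2. Within the data shown here, it concerns a different exchange and gives no size for this one, so no measured step bears directly on the change. The expectation therefore rests on compound 3 at 31 nM, with a wide margin, and a loss seems more likely than a gain. The step expected is a 3.9-fold higher number from compound 3 to compound 4 (0.59 log units; beyond the scatter), a weakening in this assay. For compound 4 the estimated value is 120 nM, with an expected range of 25 nM to 600 nM.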

Compound 4, half-maximal inhibitory concentration: 220 nM
For compound 4 the middle estimate is 1.8-fold (0.26 log units) below the measured one, and the stated range covers the measured number.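

In this assay, the exchange of 1,3-thiazol-5-yl for 4-methylpiperazin-1-yl, on an aromatic carbon para to a large group, gives a 7.1-fold higher number from compound 3 to compound 4 (0.85 log units; beyond the scatter). Within the data shown here, this is the first step of readable size in the set, since the only earlier step cannot be read, and it shows that activity at this position depends on the group placed there, while a non-aromatic ring still leaves compound 4 with an actual number rather than a limit. Nothing shown gives a cause for the size of this step.

The compounds shown leave open whether the change in activity follows the loss of the aromatic ring or some other difference between the two groups. A morpholine ring, a dimethylamino group or a pyridine ring at this position could help to separate these possibilities.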